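This account rests on a few compounds, and the source may have more. Where it says the series, first, only, none or still open, it means among the compounds named here.

Measured so far in a functional assay on MDA-MB-436 cells (Homo sapiens) for antiproliferative activity, read by MTT assay, with a stated time of 48 h; on this read-out lower numbers stand for stronger inhibition and higher numbers for weaker inhibition:
- compound 1 `CN1CCN(c2ccc(-c3cc4c(N5CCN(C(=O)Nc6ccccc6F)CC5)ncnc4s3)cc2)CC1`: 14300 nM
- compound 2 `CN1CCN(c2ccc(-c3cc4c(N5CCN(C(=O)Nc6cccc(F)c6)CC5)ncnc4s3)cc2)CC1`: 18300 nM
- compound 3 `CN1CCN(c2ccc(-c3cc4c(N5CCN(C(=O)Nc6ccc(F)cc6F)CC5)ncnc4s3)cc2)CC1`: 20200 nM

Compound 3 sits in one cluster with the other two compounds, with no separation beyond the scatter. The steps that place it are a 1.4-fold higher number from compound 1 to compound 3 (0.15 log units; within the scatter) and a 1.1-fold higher number from compound 2 to compound 3 (0.04 log units; within the scatter).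

Compound 4 `CN1CCN(c2ccc(-c3cc4c(N5CCN(C(=O)Nc6cc(C(F)(F)F)ccc6F)CC5)ncnc4s3)cc2)CC1` carries 2-fluoro-5-(trifluoromethyl)phenyl in place of 2,4-difluorophenyl on an amide-type nitrogen.

The closest evidence is the set of fluoro changes on this same group, which includes a 1.3-fold higher number from compound 1 to compound 2 (0.11 log units; within the scatter). Among the compounds with values here, all three measured steps are small, but none of them brings in a trifluoromethyl group, so the data offer no direct precedent for that part of the change. No step beyond the scatter is therefore expected in this assay, and the range is kept wide. The estimated step is a 1.1-fold lower number from compound 3 to compound 4 (0.05 log units; within the scatter). For compound 4 the expected value is 18000 nM, with an estimated range of 8000 nM to 40000 nM.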

Compound 4, half-maximal inhibitory concentration: 8840 nM
Estimate against measurement, compound 4: 2.0-fold (0.31 log units) above; the range from low to high includes it.
By their numbers in this assay, from the lowest: compounds 4, 1, 2 and 3 (each within the scatter of the next, the first and the last beyond it).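

In this assay, within the data shown here, 2-fluoro-5-(trifluoromethyl)phenyl on the amide-type nitrogen gives the first separation in this set, modest in size: a 2.3-fold lower number from compound 3 to compound 4 (0.36 log units; beyond the scatter) and a 2.1-fold lower number from compound 2 to compound 4 (0.32 log units; beyond the scatter) both lie beyond the scatter, which no fluoro-only change among the earlier compounds did. Among these compounds, the separation is not complete, since the single trifluoromethyl-for-hydrogen change gives a 1.6-fold lower number from compound 1 to compound 4 (0.21 log units; within the scatter), so compound 4 stands apart from compound 2 and compound 3 but not from compound 1. No measurement at hand accounts for the step.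

The compounds shown leave open whether a chloro, methyl or nitrile group in place of the trifluoromethyl would behave in the same way. Also open, on these data alone, is whether a plain phenyl on the same nitrogen would sit with these four compounds.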